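Shortening the Chain on the Ether Side of the Core

The source may report more compounds than this note shows. Statements on the series, on what has been measured and on what is new or still open speak of the compounds shown alone.

Compound 3 `CCC1(Cc2ccccc2)OS(=O)(=O)C=C1OCCCc1ccccc1` carries a phenethyl group on a saturated chain carbon bound to an oxygen on an unsaturated carbon. In an ADME assay on HEL cells (Homo sapiens) for cytotoxicity, with a stated time of 3 days (a lower number here means that less compound is tolerated, a higher number that more compound is tolerated), compound 3 gives 133000 nM, the highest of the two numbers shown. Compound 2 `CCC1(Cc2ccccc2)OS(=O)(=O)C=C1OCc1ccccc1Cl` gives 38000 nM, and the step of a 3.5-fold higher number from compound 2 to compound 3 (0.54 log units; beyond the scatter) is beyond the scatter. Compound 1 `CCC1(Cc2ccccc2)OS(=O)(=O)C=C1OCC#N` gives only a limit of this assay, > 200000 nM. Compound 4 `CCC1(Cc2ccccc2)OS(=O)(=O)C=C1OCCc1ccccc1` differs from compound 3 by phenyl in place of benzyl on a saturated chain carbon, two bonds along the chain from an oxygen on an unsaturated carbon. The steps of an at least 1.5-fold lower number from compound 1 to compound 3 (0.17 log units; that floor lies within the scatter) and a 3.5-fold higher number from compound 2 to compound 3 (0.54 log units; beyond the scatter) bear on this change: a benzyl ether with a ring halogen gave a clearly lower number than the longer phenethyl chain. Compound 4 sits between those two in chain length, so a modest drop is expected, a 1.9-fold lower number from compound 3 to compound 4 (0.28 log units; within the scatter). Compound 4 is therefore estimated at 70000 nM, within a range from 30000 nM to 200000 nM.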

Compound 4, half-maximal cytotoxic concentration: 48000 nM
Compound 4: middle estimate off by 1.5-fold (0.16 log units), on the high side, within the range that was stated.
By their numbers in this assay, from the lowest: compounds 2 and 4 (each within the scatter of the next); then compound 3. At a limit, above all of these: compound 1.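

Trimming the chain on this carbon matters, with phenyl in place of benzyl giving a 2.8-fold lower number from compound 3 to compound 4 (0.44 log units; beyond the scatter). Chain length alone therefore moves the number, with no ring halogen involved. Compound 2 and compound 4 are not separated, since benzyl in place of 2-chlorophenyl gives a 1.3-fold higher number from compound 2 to compound 4 (0.10 log units; within the scatter). Compound 1 gives only a limit, so an at least 4.1-fold lower number from compound 1 to compound 4 (0.61 log units; beyond the scatter) is a floor, not a measured size: the limit of > 200000 nM in this assay, at which 1 of the 4 values shown sits.

On these data alone, whether a chain longer than that of compound 3 would raise the number further stays open. So does the effect of an amine or a carboxylic acid at the end of this chain.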